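This account rests on a few compounds, and the source may have more. Where it says the series, first, only, none or still open, it means among the compounds named here.

Of the compounds shown here, three that share one core have been tested in an assay on FRT-Jurkat cells for inhibition of nuclear factor NF-kappa-B complex (Homo sapiens), read by flow cytometry, with a stated time of 24 h, tested at 10 uM; a higher number here means more inhibition at the concentration tested (going by the name of the read-out), a lower number less inhibition. Compound 1 `CCCc1ccc(Nc2cccc3c2C(=O)N(C2CCC(=O)NC2=O)C3=O)cc1` gives 23%; compound 2 `O=C1CCC(N2C(=O)c3ccc(Nc4ccccn4)cc3C2=O)C(=O)N1` gives 9%; compound 3 `CC(C)c1ccc(Nc2ccc3c(c2)C(=O)N(C2CCC(=O)NC2=O)C3=O)cc1` gives 11%. Compound 1 stands highest of the three, beyond the scatter from both of the others. Going by the values given here, the only measured change between two compounds, a number 2 percentage points higher from compound 2 to compound 3 (within the scatter), exchanges one ring group for another and so says nothing direct about lengthening a chain. Compound 4 `CCCCCc1ccc(Nc2cccc3c2C(=O)N(C2CCC(=O)NC2=O)C3=O)cc1` differs from compound 1 by ethyl in place of hydrogen on a saturated chain carbon, three bonds along the chain from an aromatic carbon, that is, propyl to pentyl. Among the compounds with values here, with no measured step bearing on this kind of change, the step of a number 3 percentage points higher from compound 1 to compound 4 (within the scatter) is expected to be small, within the scatter. Compound 4 is therefore estimated at 26%, with a range from 10% to 42%.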

Compound 4, a percentage reported as inhibition, at one concentration (the size of the read-out at that concentration, not a potency): 23%
For compound 4 the middle estimate is 3 percentage points above the measured one; the range from low to high includes it.
By their numbers in this assay, from the lowest: compounds 2 and 3 (each within the scatter of the next); then compounds 1 and 4 (each within the scatter of the next).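

Lengthening propyl to pentyl gives no change at the digits printed from compound 1 to compound 4 (within the scatter) in this assay. Going by these compounds alone, this is the first measured step at this position, three bonds along the chain from an aromatic carbon, and it shows that adding ethyl there leaves the inhibition read-out unmoved. Nothing measured here offers an explanation for this result. The compounds shown leave open whether a longer chain such as octyl, or a chain ending in an amine or a carboxylic acid, would shift the number. They also leave open whether pentyl would read the same on the core of compound 3.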